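A few compounds are considered here, and "the series" means these few. Any claim that something is new, unique, unknown or untested is made for them only; others in the source may bear on it.

Measured in a functional assay on SH-SY5Y cells (Homo sapiens) for cytotoxicity, read by MTT assay, with stated times of 8 h, 30 min and 12 h, tested at 0.5 uM; on this read-out lower numbers stand for a weaker effect and higher numbers for a stronger effect at the one concentration tested:
compound 1 `COc1ccc(CNC(=N)[C@@H]2CCC(=O)N2Cc2ccccc2)cc1`, 23.6%
compound 2 `N=C(NCc1ccccc1)[C@@H]1CCC(=O)N1Cc1ccccc1[N+](=O)[O-]`, 28.8%
compound 3 `N=C(NCc1ccc(O)cc1)[C@@H]1CCC(=O)N1Cc1ccccc1[N+](=O)[O-]`, 26.9%

Compound 3 stands second highest of the three, and its gaps to compound 2 and to compound 1 both lie within the scatter. Compound 4 `COc1ccc(CNC(=N)[C@@H]2CCC(=O)N2Cc2ccccc2[N+](=O)[O-])cc1` differs from compound 3 by methyl in place of hydrogen on an oxygen on an aromatic ring. Among the compounds with values here, the one measured step that bears on this is the entry of hydroxy in the same benzyl group, a number 1.9 percentage points lower from compound 2 to compound 3 (within the scatter), which lay within the scatter. Compound 1 and compound 2 likewise show no separation beyond the scatter on this read-out. No step beyond the scatter is therefore expected, the estimated step being a number 0.9 percentage points lower from compound 3 to compound 4 (within the scatter). Compound 4 is expected to give 26%, with a range of 17% to 35%.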

Compound 4, a percentage reported as activity, at one concentration (the size of the read-out at that concentration, not a potency): 21.1%
Compound 4: the middle estimate sits 4.9 percentage points above what was measured, within the range that was stated.
By their numbers in this assay, from the lowest: compounds 4, 1, 3 and 2 (each within the scatter of the next).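

In this assay, methoxy at this place cannot be told apart from hydroxy: a number 5.8 percentage points lower from compound 3 to compound 4 (within the scatter). Methoxy also stays within the scatter against hydrogen on the same aromatic carbon: a number 7.7 percentage points lower from compound 2 to compound 4 (within the scatter). Within the data shown here, with methoxy held fixed, the nitro group gives the first single-place comparison for that group, and it also stays within the scatter: a number 2.5 percentage points lower from compound 1 to compound 4 (within the scatter). Still open, as far as these compounds go, is whether an amine or a carboxylic acid on this benzyl group, or a longer chain on the oxygen, moves the read-out beyond the scatter. No available data speak to the reason for these numbers.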